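Azidoacetyl replaces propanoyl on the shared amide core

The source may hold more compounds than are shown below. What is called first, only, known or untested is meant among the compounds shown, and "the series" means these compounds.

Measured compounds in a functional assay on MGC-803 cells (Homo sapiens) for inhibition, read by MTT assay, with a stated time of 48 h; on this read-out lower numbers stand for stronger inhibition and higher numbers for weaker inhibition:
compound 1 `CCC(=O)N(Cc1ccc(OC)c(O)c1)c1cc(OC)c(OC)c(OC)c1` gives 50 nM
compound 2 `COc1ccc(N(Cc2cc(OC)c(OC)c(OC)c2)C(=O)CCl)cc1O` gives 24500 nM
compound 3 `COc1cc(NCc2cccc(O)c2)cc(OC)c1OC` gives 57600 nM

Compound 1 holds the lowest number of the three in this assay, and its separation from compound 2 and from compound 3 lies beyond the scatter in both cases. Compound 2 carries a chloroacetyl amide on the same core with the two aryl parts exchanged, and compound 3 has no amide at all; both fall far from compound 1.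

Compound 4 `COc1ccc(CN(C(=O)CN=[N+]=[N-])c2cc(OC)c(OC)c(OC)c2)cc1O` is not yet measured. It differs from compound 1 in one place: azido in place of methyl on a saturated chain carbon bound to a carbonyl carbon. The amide itself and the two aromatic parts of compound 1 are kept unchanged.

For the measured compounds named here, no measured pair shows this exact change alone, so the direction rests on compound 1 as the single anchor. The step from compound 1 to compound 4 is expected to read a 6.0-fold higher number from compound 1 to compound 4 (0.78 log units; beyond the scatter), a moderate weakening, since the only other acetyl-type amide present, compound 2, gives 24500 nM while also differing in the arrangement of its aryl groups. Compound 4 is estimated at 300 nM in this assay, with a range from 50 nM to 3000 nM.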

Compound 4, half-maximal inhibitory concentration: 120 nM
Compound 4: middle estimate off by 2.5-fold (0.40 log units), on the high side, within the range that was stated.
By their numbers in this assay, from the lowest: compound 1; then compound 4; then compound 2; then compound 3.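

In this assay, for the compounds shown here, the change from methyl to azido on a saturated chain carbon bound to a carbonyl carbon gives a 2.4-fold higher number from compound 1 to compound 4 (0.38 log units; beyond the scatter) and is the first one-place comparison. The step is modest but beyond the scatter, so this position takes three heavy atoms in place of one, and one hydrogen-bond acceptor where methyl has none, while compound 4 remains at 120 nM in this assay. Nothing available bears on why the number rises.

The compounds shown leave open how an amine, a hydroxyl or a nitrile would read at this place, and whether a longer chain ending in azido would stay close to compound 1. A single step also gives no trend across groups at this position.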